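Swapping One Bromophenyl for Another

This account rests on a few compounds, and the source may have more. Where it says the series, first, only, none or still open, it means among the compounds named here.

In an ADME assay on Vero cells (Chlorocebus sabaeus) for cytotoxicity, read by MTT assay, with a stated time of 72 h (a higher number here means that more compound is needed for the effect, a lower number that less compound is needed), compound 1 `Cc1cccc(C(=O)Nc2nc(-c3ccccn3)cs2)c1` gives 4100 nM and compound 2 `O=C(Nc1nc(-c2ccccn2)cs1)c1ccccc1Br` gives 3500 nM. These two sit close together, with a 1.2-fold lower number from compound 1 to compound 2 (0.07 log units; within the scatter). Compound 3 `O=C(Nc1nc(-c2ccccn2)cs1)c1cccc(Br)c1` gives 16100 nM and has the highest number of the three, so it takes the most compound to produce the effect. Two measured steps lead up to it: a 3.9-fold higher number from compound 1 to compound 3 (0.59 log units; beyond the scatter) and a 4.6-fold higher number from compound 2 to compound 3 (0.66 log units; beyond the scatter).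

Compound 4 `O=C(Nc1nc(-c2ccccn2)cs1)c1ccc(Br)cc1` has not been measured yet. It has the same atoms as compound 3, joined differently, with 4-bromophenyl in place of 3-bromophenyl on a carbonyl carbon. For the measured compounds named here, the closest precedent is the step from compound 2, the only measured swap of one bromophenyl for another. It shows that such a swap can shift the number modestly, but it cannot tell the direction for this new group. Compound 3 is the top of a small set, so a small move downward seems the likelier outcome, and a result within the scatter would be no surprise. The expected change is a 1.6-fold lower number from compound 3 to compound 4 (0.21 log units; within the scatter). For compound 4 the estimated value is 10000 nM, with an expected range from 3500 nM to 25000 nM.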

Compound 4, half-maximal effective concentration: 4700 nM
Compound 4: middle estimate off by 2.1-fold (0.33 log units), on the high side; low and high end bracket the measured number.
By their numbers in this assay, from the lowest: compounds 2, 1 and 4 (each within the scatter of the next); then compound 3.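

In this assay, moving the bromo group to give the 4-bromophenyl group produces a 3.4-fold lower number from compound 3 to compound 4 (0.53 log units; beyond the scatter) and shows that the high number of compound 3 is not shared by every bromophenyl group on this carbonyl carbon. The other two new steps are small, namely a 1.3-fold higher number from compound 2 to compound 4 (0.13 log units; within the scatter) and a 1.1-fold higher number from compound 1 to compound 4 (0.06 log units; within the scatter) and so the 2-bromophenyl and 4-bromophenyl groups cannot be told apart here, leaving the 3-bromophenyl group as the one bromophenyl group that stands out among those shown. Compound 1 goes against any rule based on the ring number alone, since its 3-methylphenyl group carries the same number as the 3-bromophenyl group of compound 3, yet its value lies within the scatter of those of compound 2 and compound 4.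

The data shown offer no explanation for why compound 3 stands apart from the other three. Still open, going by these compounds, is where a 3-chlorophenyl, 3-aminophenyl or 3-carboxyphenyl group would fall in this assay and whether the higher number is specific to the 3-bromophenyl group.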